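Hydrogen for methyl on the aromatic nitrogen of compound 2

The compounds below may be only part of what the source reports. "The series", "measured", "known", "first", "only" and "open" are said of these compounds alone.

Measured in a toxicity assay on HEK293 cells (Homo sapiens) for inhibition, read by resazurin assay, with a stated time of 24 h; a lower number here means that less compound is tolerated, a higher number that more compound is tolerated:
Compound 1 `Cn1c([N+](=O)[O-])cnc1C(=O)N1CCCC1`: > 100000 nM, a limit.
Compound 2 `Cn1c([N+](=O)[O-])cnc1C(=O)NC1CC1`: > 100000 nM, a limit.
Compound 3 `Cn1c([N+](=O)[O-])cnc1C(=O)NC1CCCCC1`: > 100000 nM, a limit.

Compound 2 offers only a limit, and it shares that position with the whole set: the limit of > 100000 nM in this assay, at which 3 of the 3 values shown sit.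

Compound 4 `O=C(NC1CC1)c1ncc([N+](=O)[O-])[nH]1` differs from compound 2 as follows: hydrogen in place of methyl on an aromatic nitrogen.

Among the measured compounds shown here, two measured steps bear on this only loosely: a step that the two limits leave unreadable from compound 1 to compound 2 and a step that the two limits leave unreadable from compound 2 to compound 3. Neither touches the aromatic nitrogen, and neither has a readable size. No step beyond the scatter is therefore expected in this assay, in either direction. The estimated step is a number no higher from compound 2 to compound 4 (the limit leaves the size open). For compound 4 the estimated value is 100000 nM, with an expected range of 50000 nM to 200000 nM.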

Compound 4, half-maximal cytotoxic concentration: > 100000 nM
Compound 4: only a limit was reported; the forecaster's own chance of this, stated with the estimate: 85%; the middle value lies on the limit itself.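

No step can be read from compound 2 to compound 4 in this assay, with both values reported only as limits: the limit of > 100000 nM in this assay, at which 4 of the 4 values shown sit.

The compounds shown leave open whether hydrogen in place of methyl on the aromatic nitrogen shifts the half-maximal cytotoxic concentration at all.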